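The compounds below may be only part of what the source reports. "The series", "measured", "known", "first", "only" and "open" are said of these compounds alone.

The account begins with compound 1, whose structure is `NC1=NC2(CCOCC2)N(OCCCOc2ccccc2)C(N)=N1`. In an assay on isolated protein for inhibition of Dihydrofolate reductase (Homo sapiens), read by spectrophotometry, using NADPH, with stated times of 5 s and 6 min, tested at 50 uM (a lower number here means a weaker effect, a higher number a stronger effect of the compound at the concentration tested), compound 1 gives "not determined" (no result reported), so it stands without a single number against which a step could be measured. Two companions of the same series are known. Compound 2, `NC1=NC2(CCSCC2)N(OCCCOc2cccc(Cl)c2)C(N)=N1`, is the only one with a reported figure: in this assay compound 2 gives 88.8%. Compound 3, `NC1=NC2(CCSCC2)N(OCCCOc2ccc(Br)cc2)C(N)=N1`, resembles compound 2 in its core but carries a different substituent; in this assay compound 3 gives "not determined" (no result reported), again no number. Compound 4, `Cc1cc(C)cc(OCCCON2C(N)=NC(N)=NC23CCOCC3)c1`, is the one still to be measured. It differs from compound 1 in a single place: 3,5-dimethylphenyl in place of phenyl on an oxygen on a saturated carbon. For the measured compounds named here, with no number for compound 1 and no step between measured pairs, the size of the change on going to compound 4 cannot be read from the series; a shift beyond the usual scatter is not expected in either direction, though the only anchor is compound 2. Compound 4 is therefore estimated to reach about 80% in this assay, expected to fall between 55% and 97%.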

Compound 4, a percentage reported as inhibition, at one concentration (the size of the read-out at that concentration, not a potency): 88.6%
Beside the measured number, compound 4's estimate is 8.6 percentage points below it; the measured number falls inside the stated range.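

In this assay, for the compounds shown here, compound 1 gives "not determined" (no result reported), so no new step to compound 4 can be read. From the compounds shown here alone, what 3,5-dimethylphenyl in place of phenyl does to the inhibition therefore stays open. No evidence bearing on the result of compound 4 is available.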